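The source may report more compounds than this note shows. Statements on the series, on what has been measured and on what is new or still open speak of the compounds shown alone.

Measured so far in an assay on HEK293 cells for agonist activity at transient receptor potential cation channel subfamily M member 8 (Homo sapiens), read by fluorescence and calcium flux, with a stated time of 15 min; on this read-out lower numbers stand for an effect already at smaller amounts and higher numbers for an effect only at larger amounts of compound:

compound 1 `CCN(Cc1c[nH]nn1)C(=O)COc1ccc(C)cc1`: 31100 nM
compound 2 `CCN(Cc1cccs1)C(=O)c1cc2cc(C)ccc2s1`: 1600 nM
compound 3 `Cc1ccc(OCC(=O)N(Cc2cccs2)c2cn[nH]c2)cc1`: 1.4 nM

Compound 1 stands at the highest number of the three in this assay ; compound 2 sits nearest to it, compound 3 furthest, and both gaps are beyond the usual scatter. Within the data shown here, compound 3 shares the core of compound 1, so the core itself does not fix the number; the groups on the amide-type nitrogen evidently matter, but no pair of measured compounds isolates any single such group.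

Compound 4 `CCN(Cc1ccccn1)C(=O)COc1ccc(C)cc1` is not yet measured. It differs from compound 1 in one place: pyridin-2-yl in place of 1H-1,2,3-triazol-4-yl on a saturated chain carbon bound to an amide-type nitrogen. Among the measured compounds shown here, no measured pair shows this exchange, so the size of the step is open. For the measured compounds named here, the loss of the hydrogen-bond donor on the five-membered ring is the only counted change; with nothing comparable in the measured set, a step of modest size in either direction is about as likely as none beyond the scatter. Compound 4 is therefore expected near compound 1, with the estimate 18000 nM, range 4000 nM to 80000 nM, the expected step being a 1.7-fold lower number from compound 1 to compound 4 (0.24 log units; within the scatter).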

Compound 4, half-maximal effective concentration: 16000 nM
Beside the measured number, compound 4's estimate is 1.1-fold (0.05 log units) above it; the range from low to high includes it.
By their numbers in this assay, from the lowest: compound 3; then compound 2; then compounds 4 and 1 (each within the scatter of the next).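

In this assay, this first single-place exchange in the series gives a 1.9-fold lower number from compound 1 to compound 4 (0.29 log units; within the scatter), so pyridin-2-yl in place of 1H-1,2,3-triazol-4-yl on a saturated chain carbon bound to an amide-type nitrogen leaves the number within the usual scatter. The hydrogen-bond donor counted on the leaving ring is absent from the entering ring, yet no step beyond the scatter appears at this position on the core of compound 1. No supporting data are available to explain this result.

As far as these compounds go, whether the same exchange reads alike with the other groups on the amide-type nitrogen of compound 3 remains open, and no single exchange yet separates those groups. Also open, from the compounds shown here alone, is how a primary amine or a carboxylic acid on the same chain carbon would read.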